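Amide substituent swap in a furoyl aminoacetamide series

The source may report more compounds than this note shows. Statements on the series, on what has been measured and on what is new or still open speak of the compounds shown alone.

Compound 1, `C[C@H](NC(=O)C(c1cccnc1)N(C(=O)c1ccco1)c1ccc(-c2ccccn2)cc1)c1ccccc1`: 236000 nM
Compound 2, `C[C@H](NC(=O)C(c1cccnc1)N(C(=O)c1ccco1)c1ccc(-c2ccccc2)cc1)c1ccccc1`: > 200000 nM

In a toxicity assay on Vero C1008 cells (Chlorocebus sabaeus) for cytotoxicity, read by neutral red uptake, with a stated time of 5 days (a lower number here means that less compound is tolerated, a higher number that more compound is tolerated), compound 1 gives 236000 nM. For compound 2 the result is a limit of the measurement, > 200000 nM, so only a bound is known for it. The step that the limit leaves unreadable from compound 1 to compound 2 can therefore not be sized, as the limit of > 200000 nM in this assay, at which 1 of the 2 values shown sits, shows. Compound 3, `CC(C)(C)CC(C)(C)NC(=O)C(c1cccnc1)N(C(=O)c1ccco1)c1ccc(-c2ccccc2)cc1`, follows from compound 2 by the change (1,1,3,3-tetramethylbutyl in place of 1-phenylethyl on an amide-type nitrogen). Among the compounds with values here, no measured step touches the group on the amide-type nitrogen, so none of the two measured compounds bears directly on this change. Within the data shown here, the only guide is the stance of compound 2, and a step close to nothing is expected, a number no higher from compound 2 to compound 3 (the limit leaves the size open). Compound 3 is thus estimated at 200000 nM, within 80000 nM and 500000 nM, with a real chance that this assay again reports only a limit.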

Compound 3, half-maximal cytotoxic concentration: 148000 nM
Compound 3: middle estimate off by 1.4-fold (0.13 log units), on the high side, within the range that was stated.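

Compound 3 is the first compound shown with a different group on the amide-type nitrogen, and in this assay the swap of 1-phenylethyl for 1,1,3,3-tetramethylbutyl gives an at least 1.3-fold lower number from compound 2 to compound 3 (0.13 log units; that floor lies within the scatter). This floor does not show a change beyond the usual scatter, so a ring-free group of the same carbon count is not shown to alter the read-out at this position. Only a floor can be given because compound 2 carries a limit of the assay rather than a number: the limit of > 200000 nM in this assay, at which 1 of the 3 values shown sits.

The aromatic ring and the defined stereocentre leave together in this change, so the compounds shown cannot separate their contributions. They also leave open how this assay would respond to a primary amine, a carboxylic acid or a shorter chain such as tert-butyl on that nitrogen.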